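Compound 3 to compound 4: a swap on an aromatic nitrogen

The source may report more compounds than this note shows. Statements on the series, on what has been measured and on what is new or still open speak of the compounds shown alone.

- Compound 1 `CN1C(=S)[C@@H](NC(=O)c2nc(Cc3ccccc3)n(C)n2)COc2ccccc21` gives > 100000 nM as a limit in a toxicity assay on HT-29 cells (Homo sapiens) for cytotoxicity; on this read-out lower numbers stand for higher toxicity in this test and higher numbers for lower toxicity in this test
- Compound 2 `CN1C(=S)[C@@H](NC(=O)c2nc(Cc3ccccc3)n(C3CCCC3)n2)COc2ccccc21` gives > 100000 nM as a limit in this assay
- Compound 3 `CN1C(=S)[C@@H](NC(=O)c2nc(Cc3ccccc3)n(C3CCOC3)n2)COc2ccccc21` gives > 100000 nM as a limit in this assay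

In this assay compound 3 has no number and stands with the other two at the limit of > 100000 nM in this assay, at which 3 of the 3 values shown sit, and nothing ranks the three.

Compound 4 `CN1C(=S)[C@@H](NC(=O)c2nc(Cc3ccccc3)n(C3CCNCC3)n2)COc2ccccc21` carries piperidin-4-yl in place of oxolan-3-yl on an aromatic nitrogen. The swap lies next to the ring atom that bears a benzyl group.

The measured steps that bear on it change the group on the same aromatic nitrogen (a step that the two limits leave unreadable from compound 1 to compound 2) and (a step that the two limits leave unreadable from compound 1 to compound 3) and (a step that the two limits leave unreadable from compound 2 to compound 3). None of them has a readable size, so they offer no size to carry over. Methyl, cyclopentyl and oxolan-3-yl are the only groups tested at this place, and none of them is piperidin-4-yl.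

The expectation starts from compound 3, whose value (> 100000 nM) is a limit. No clear shift is expected, though a measurable number on the lower, more toxic side remains possible. The estimated step (a number no higher from compound 3 to compound 4 (the limit leaves the size open)) is expected to stay small or unreadable. The estimated value for compound 4 is (100000 nM), with an expected range (30000 nM to 100000 nM).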

Compound 4, half-maximal cytotoxic concentration: > 100000 nM
Compound 4: only a limit was reported; the forecaster's own chance of this, stated with the estimate: 80%; the middle value sits exactly at the limit.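

In this assay, within the data shown here, compound 4 gives only a limit, so no step between compound 4 and compound 1, compound 2 or compound 3 can be read, and the series has no number to compare: the limit of > 100000 nM in this assay, at which 4 of the 4 values shown sit.

The compounds shown leave open whether methyl, cyclopentyl, oxolan-3-yl and piperidin-4-yl on the aromatic nitrogen differ at all in this assay.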